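Swapping a Nitro Group for a Hydroxyethylamino Chain

A few compounds are considered here, and "the series" means these few. Any claim that something is new, unique, unknown or untested is made for them only; others in the source may bear on it.

Compound 1 `Cc1cccc(C2(CNC(=O)Nc3c(C(C)C)cccc3C(C)C)CCCC2)c1` gives 15 nM in an assay on microsomes for inhibition of acyl-CoA:cholesterol acyltransferase (Oryctolagus cuniculus); a higher number here means a weaker inhibitor, a lower number a stronger inhibitor.
Compound 2 `CC(C)c1cccc(C(C)C)c1NC(=O)NCC1(c2ccc(OCc3ccccc3)cc2)CCCC1` gives 34 nM in this assay.
Compound 3 `CC(C)c1cccc(C(C)C)c1NC(=O)NCC1(c2ccc([N+](=O)[O-])cc2)CCCC1` gives 131 nM in this assay.

All three share the same core, a urea attached to a ring that carries a second aromatic ring, and differ only in the group on that second ring. Compound 3 stands at the highest number of the three, so it is the weakest inhibitor shown: the step is an 8.7-fold higher number from compound 1 to compound 3 (0.94 log units; beyond the scatter), and a 3.9-fold higher number from compound 2 to compound 3 (0.59 log units; beyond the scatter).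

Compound 4 `CC(C)c1cccc(C(C)C)c1NC(=O)NCC1(c2ccc(NCCO)cc2)CCCC1` has not been measured. It differs from compound 3 as follows: (2-hydroxyethyl)amino in place of nitro on an aromatic carbon. Among the measured compounds shown here, two measured steps bear on this change, since both end at compound 3. Going from compound 3 to either a 3-methylphenyl or a benzyloxy group gives a lower number, and both steps lie beyond the scatter. The group entering in compound 4 is, like benzyloxy, larger than nitro, so a lower number is expected for compound 4, though the direction is not certain, because a 3.9-fold higher number from compound 2 to compound 3 (0.59 log units; beyond the scatter) shows a smaller change than an 8.7-fold higher number from compound 1 to compound 3 (0.94 log units; beyond the scatter).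

For compound 4 the expected step is a 2.6-fold lower number from compound 3 to compound 4 (0.42 log units; beyond the scatter). Compound 4 is therefore estimated at 50 nM, with a range from 15 nM to 200 nM.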

Compound 4, half-maximal inhibitory concentration: 25 nM
The estimate for compound 4 lay 2.0-fold (0.30 log units) above the measured number; the measured number falls inside the stated range.
By their numbers in this assay, from the lowest: compounds 1, 4 and 2 (each within the scatter of the next, the first and the last beyond it); then compound 3.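

In this assay, the change on this aromatic carbon gives a 5.2-fold lower number from compound 3 to compound 4 (0.72 log units; beyond the scatter) and so shows that nitro can be replaced by a group with 2 hydrogen-bond donors, where nitro has 0, while the number falls beyond the scatter. Benzyloxy had already shown a lower number than nitro, but (2-hydroxyethyl)amino has only 4 heavy atoms against the 3 of nitro, and the comparison of the two larger groups gives a 1.4-fold lower number from compound 2 to compound 4 (0.13 log units; within the scatter) and places them level, so at this position a large group is not needed for the lower number. The new compound also sits level with the best compound of the set, as a 1.7-fold higher number from compound 1 to compound 4 (0.22 log units; within the scatter) shows, which leaves nitro as the only group shown here that stands apart from the others.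

Nothing measured here explains why the number moves with this change.
On these data alone, it also remains open which part of the chain matters, the nitrogen or the hydroxyl, and a simple ethylamino group, a 2-methoxyethylamino group and a longer 3-hydroxypropylamino chain at this position would help to separate the two.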